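The source may hold more compounds than are shown below. What is called first, only, known or untested is meant among the compounds shown, and "the series" means these compounds.

Measured compounds:
compound 1, `Cc1cc(C)cc(N2CCN(C(=O)c3oc(C)nc3-c3ccccc3)CC2)c1`, in a functional assay on HL-60 cells (Homo sapiens) for inhibition, read by MTT assay, with a stated time of 72 h (a higher number here means a weaker inhibitor, a lower number a stronger inhibitor), gives 34.5 nM
compound 2, `Cc1nc(-c2ccccc2)c(C(=O)N2CCN(c3cc(Cl)cc(Cl)c3)CC2)o1`, in this assay gives 41.8 nM

Compound 2 stands at the higher of the two numbers seen so far in this assay, but its nearest neighbour, compound 1, differs from it by a 1.2-fold higher number from compound 1 to compound 2 (0.08 log units; within the scatter), so the two values show no separation that can be read as order. Within the data shown here, that single step, which exchanged 3,5-dimethylphenyl for 3,5-dichlorophenyl on an amine nitrogen in a ring, is the only comparison in hand.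

Compound 3, `Cc1nc(-c2ccccc2)c(C(=O)N2CCN(c3ccccc3)CC2)o1`, has not yet been measured. It differs from compound 2 in one place: phenyl in place of 3,5-dichlorophenyl on an amine nitrogen in a ring. Among the measured compounds shown here, no measured step removes both substituents from that aromatic ring, so the step from compound 1 to compound 2 bears on it only loosely, by showing that the two substituted rings gave numbers within the scatter of each other. On that basis a step of a 1.6-fold higher number from compound 2 to compound 3 (0.19 log units; within the scatter) is expected, small and possibly not beyond the scatter. Compound 3 is therefore estimated at 65 nM in this assay, with a range of 20 nM to 220 nM.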

Compound 3, half-maximal inhibitory concentration: 39.1 nM
Estimate against measurement, compound 3: 1.7-fold (0.22 log units) above; the range from low to high includes it.
By their numbers in this assay, from the lowest: compounds 1, 3 and 2 (each within the scatter of the next).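

In this assay, taking both substituents off the aromatic ring on the amine nitrogen leaves the number within the scatter, whether the change starts from the 3,5-dichlorophenyl group (a 1.1-fold lower number from compound 2 to compound 3 (0.03 log units; within the scatter)) or from the 3,5-dimethylphenyl group (a 1.1-fold higher number from compound 1 to compound 3 (0.05 log units; within the scatter)). The earlier pair compared only two substituted rings, whereas compound 3 adds the plain phenyl ring and shows that, among these three compounds, neither pair of substituents is separated from having no substituent at all. No outside evidence bears on why these three numbers lie so close together.

The compounds shown leave open whether this position stays as undemanding with a carboxylic acid or an amine on the phenyl ring, or with a pyridine or cyclohexyl ring in place of the phenyl ring. They also leave open how much the shared core contributes to these values, as all three compounds carry it unchanged and differ only in the group on the amine nitrogen.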